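A Cyclohexylmethyl Group on the Amine Nitrogen

The compounds below may be only part of what the source reports. "The series", "measured", "known", "first", "only" and "open" are said of these compounds alone.

- Compound 1 (`FC1(F)CCC(CN(C[C@H]2Cc3c(cccc3N3CCNCC3)CN2)[C@H]2CCCc3cccnc32)CC1`): 68.6%
- Compound 2 (`CC(C)N(C[C@H]1Cc2c(cccc2N2CCNCC2)CN1)[C@H]1CCCc2cccnc21`): 75%

In an ADME assay on microsomes from liver (Homo sapiens) for metabolic stability, read by LC-MS, with a stated time of 10 min (a higher number here means that more of the compound is left, a lower number that less of the compound is left), compound 2 gives 75%, which lies within the usual scatter of compound 1 at 68.6%. Compound 3 (`c1cnc2c(c1)CCC[C@@H]2N(CC1CCCCC1)C[C@H]1Cc2c(cccc2N2CCNCC2)CN1`) has cyclohexylmethyl in place of isopropyl on an amine nitrogen. Going by the values given here, only one measured step bears on this change. It is a number 6.4 percentage points higher from compound 1 to compound 2 (within the scatter), with isopropyl in place of (4,4-difluorocyclohexyl)methyl on an amine nitrogen. That departing group also holds a six-membered non-aromatic ring, so it is the closest measured match to cyclohexylmethyl. Returning to such a group should therefore bring a small downward move, with no change beyond the scatter. The expected change is a number 8 percentage points lower from compound 2 to compound 3 (within the scatter). For compound 3 the estimated value is 67%, with an expected range from 54% to 79%.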

Compound 3, percent of the compound remaining: 81.6%
For compound 3 the middle estimate is 14.6 percentage points below the measured one; measured number outside the range, above it.
By their numbers in this assay, from the lowest: compounds 1, 2 and 3 (each within the scatter of the next, the first and the last beyond it).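

On this amine nitrogen, a group with a six-membered ring and 7 heavy atoms does no measurable harm compared with isopropyl and its 3 heavy atoms: in this assay the step is a number 6.6 percentage points higher from compound 2 to compound 3 (within the scatter), so the two groups cannot be told apart here. The clearer contrast lies within the ring-bearing groups, where cyclohexyl in place of 4,4-difluorocyclohexyl on the saturated chain carbon gives a number 13 percentage points higher from compound 1 to compound 3 (beyond the scatter), so the version without fluorine keeps more compound intact. No measured information here explains this difference.

On these data alone, how a benzyl group or a piperidin-4-ylmethyl group would behave on this nitrogen remains open. So does whether a cyclohexyl ring carrying a single fluorine would fall with compound 1 or with compound 3.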